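From compound 2 to compound 3: an isomeric side chain

The compounds below may be only part of what the source reports. "The series", "measured", "known", "first", "only" and "open" are said of these compounds alone.

In a functional assay on HL-60 cells (Homo sapiens) for cytotoxicity, read by MTT assay, with a stated time of 48 h (on this read-out higher numbers stand for weaker inhibition and lower numbers for stronger inhibition), compound 1 (`CC(C)CN1Cc2c(ccc([C@@]3(C)CCCC(C)(C)C3)c2[C@@H](C)C(=O)O)C1=O`) gives > 10000 nM, which is a limit of the assay. Compound 2 (`CCC(C)CN1Cc2c(ccc([C@@]3(C)CCCC(C)(C)C3)c2[C@@H](C)C(=O)O)C1=O`) gives > 10000 nM, again a limit and not a number. For the measured compounds named here, compound 2 therefore has no measured position in this assay, and the one other reading is also a limit. The evidence so far is the limit of > 10000 nM in this assay, at which 2 of the 2 values shown sit. Going by the values given here, the single measured step, a step that the two limits leave unreadable from compound 1 to compound 2, gives no size to carry forward.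

Compound 3 (`CC(C)CCN1Cc2c(ccc([C@@]3(C)CCCC(C)(C)C3)c2[C@@H](C)C(=O)O)C1=O`) is not yet measured. The change from compound 2 to compound 3 is isobutyl in place of sec-butyl on a saturated chain carbon bound to an amide-type nitrogen in a ring, which also reads as 2-methylbutyl to isopentyl.

With no readable step, no move beyond the scatter is expected in either direction, and another limit is the likeliest report. This expectation rests on compound 2, whose reading of > 10000 nM is a limit. The estimated step is a step that the limit leaves unreadable from compound 2 to compound 3. For compound 3 the expected value is 14000 nM, with an estimated range of 6000 nM to 35000 nM.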

Compound 3, half-maximal inhibitory concentration: > 10000 nM
Compound 3: a limit, no number; the forecaster's own chance of this, stated with the estimate: 80%; the middle value lies beyond the limit too.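

In this assay compound 3 gives > 10000 nM, which is a limit and not a number. No new step can be read among compound 1, compound 2 and compound 3, as all three readings are limits: the limit of > 10000 nM in this assay, at which 3 of the 3 values shown sit.

On these data alone, whether these three compounds differ from one another in this assay stays open.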